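Mirror-image change at the chain carbon of compound 1

The source may hold more compounds than are shown below. What is called first, only, known or untested is meant among the compounds shown, and "the series" means these compounds.

Measured so far:
compound 1 `CC[C@H](C)/N=c1\c(O)c(O)\c1=N/Cc1ccc(C#N)cc1` — 2200 nM
compound 2 `CCC(C)(C)/N=c1\c(O)c(O)\c1=N/Cc1ccc(C)c(C)c1` — > 30000 nM

For the measured compounds named here, in a functional assay for inhibition, with Rattus norvegicus as the target (a lower number here means a stronger inhibitor, a higher number a weaker inhibitor), compound 1 gives 2200 nM, the only number this set has produced. For compound 2 this assay reports a limit, > 30000 nM, not a number; the limit of > 30000 nM in this assay, at which 1 of the 2 values shown sits, marks where it sits. Compound 3 `CC[C@@H](C)/N=c1\c(O)c(O)\c1=N/Cc1ccc(C#N)cc1` differs from compound 1 in one respect: the two compounds have the same atoms and bonds and differ only in configuration as drawn: 1 of 3 stereo elements differ; a stereocentre at a saturated chain carbon is drawn S in compound 1 and R in compound 3. Going by the values given here, no measured pair isolates such a change, so its size is unknown; a step of modest size in either direction is expected, a 1.8-fold higher number from compound 1 to compound 3 (0.26 log units; within the scatter). Compound 3 is estimated at 4000 nM, within 600 nM to 25000 nM.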

Compound 3, half-maximal inhibitory concentration: 4000 nM
Compound 3: middle estimate and measured number agree at the digits printed; the measured number falls inside the stated range.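

Measured in this assay the change from S to R at the saturated chain carbon amounts to a 1.8-fold higher number from compound 1 to compound 3 (0.26 log units; within the scatter) and so does not separate the two configurations. For the compounds shown here, this pair is the first in the set to isolate configuration at this carbon, with atoms and bonds unchanged. Compound 2 differs from compound 1 in more than one place and offered no such reading.

The compounds shown leave open whether a longer chain or a cyclopropyl group at this carbon would change the number, and whether the two configurations would still match with an amine in place of the nitrile.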